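Aryl amine variation on the trifluoromethylbenzylthio quinazoline series

This account rests on a few compounds, and the source may have more. Where it says the series, first, only, none or still open, it means among the compounds named here.

Compound 1 `Fc1ccc(Nc2nc(SCc3ccc(C(F)(F)F)cc3)nc3ccccc23)cc1` is measured in a functional assay on MDA-MB-231 cells (Homo sapiens) for cytotoxicity, read by MTT assay, with a stated time of 72 h (a higher number here means a weaker inhibitor, a lower number a stronger inhibitor), at 15000 nM. Compound 2 `COc1ccc(Nc2nc(SCc3ccc(C(F)(F)F)cc3)nc3ccccc23)cc1` gives 15700 nM in this assay, and the step of a 1.0-fold higher number from compound 1 to compound 2 (0.02 log units; within the scatter) leaves the two numbers within the scatter of each other; compound 2 therefore stands level with compound 1 on the numbers shown. Compound 3 `COc1cc(Nc2nc(SCc3ccc(C(F)(F)F)cc3)nc3ccccc23)cc(OC)c1` carries 3,5-dimethoxyphenyl in place of 4-methoxyphenyl on a nitrogen on an aromatic ring. Only the fluoro-to-methoxy step bears on this change, and it was flat, so no step beyond the scatter is expected in this assay. Compound 3 is expected at 16000 nM, range 6000 nM to 45000 nM. The estimated step of a 1.0-fold higher number from compound 2 to compound 3 (0.01 log units; within the scatter) is within the scatter.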

Compound 3, half-maximal inhibitory concentration: 16100 nM
For compound 3 the middle estimate is 1.0-fold (0.00 log units) below the measured one, and the stated range covers the measured number.
By their numbers in this assay, from the lowest: compounds 1, 2 and 3 (each within the scatter of the next).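

In this assay, 3,5-dimethoxyphenyl on the nitrogen leaves the result flat, with a 1.0-fold higher number from compound 2 to compound 3 (0.01 log units; within the scatter) and a 1.1-fold higher number from compound 1 to compound 3 (0.03 log units; within the scatter). This position therefore accepts two methoxy groups in place of the single methoxy of 4-methoxyphenyl or the fluoro of 4-fluorophenyl, with no step beyond the scatter. No measurement shown offers an explanation for this flat result. Still open, from the compounds shown here alone, is whether an amine or a carboxylic acid on this aromatic ring, or a longer chain in place of the ring, would give a step beyond the scatter.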